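The source may report more compounds than this note shows. Statements on the series, on what has been measured and on what is new or still open speak of the compounds shown alone.

- Compound 1 `OC[C@H]1O[C@@H](n2cnc3c(CSCc4ccccc4)ncnc32)[C@H](O)[C@@H]1O`: 4650 nM
- Compound 2 `OC[C@H]1O[C@@H](n2cnc3c(COc4ccccn4)ncnc32)[C@H](O)[C@@H]1O`: 10800 nM

In a functional assay on CCRF-CEM cells (Homo sapiens) for inhibition, read by XTT assay, with a stated time of 72 h (a lower number here means a stronger inhibitor, a higher number a weaker inhibitor), compound 2 gives 10800 nM, the higher of the two numbers. Compound 3 `CSCc1ncnc2c1ncn2[C@@H]1O[C@H](CO)[C@@H](O)[C@H]1O` differs from compound 2 as follows: methylsulfanyl in place of (pyridin-2-yl)oxy on a saturated chain carbon bound to an aromatic carbon. That is, it has methylsulfanyl in place of (pyridin-2-yl)oxy on a saturated chain carbon bound to an aromatic carbon. Among the compounds with values here, only one measured step bears on this: a 2.3-fold higher number from compound 1 to compound 2 (0.37 log units; beyond the scatter), a modest one that replaced benzylsulfanyl with (pyridin-2-yl)oxy. Within the data shown here, compound 3 again carries a sulfanyl group, although no measured compound has methylsulfanyl, so a similarly modest move to a lower number is expected. The expected change is a 2.2-fold lower number from compound 2 to compound 3 (0.33 log units; beyond the scatter). For compound 3 the estimated value is 5000 nM, with an expected range of 1300 nM to 19000 nM.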

Compound 3, half-maximal inhibitory concentration: 3200 nM
Compound 3: the middle estimate sits 1.6-fold (0.19 log units) above what was measured; measured number inside the range.
By their numbers in this assay, from the lowest: compounds 3 and 1 (each within the scatter of the next); then compound 2.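

In this assay, methylsulfanyl gives a lower number than (pyridin-2-yl)oxy on this saturated chain carbon, with a 3.4-fold lower number from compound 2 to compound 3 (0.53 log units; beyond the scatter). Hydrogen in place of phenyl on the carbon bound to sulfur gives a 1.5-fold lower number from compound 1 to compound 3 (0.16 log units; within the scatter), so the small and large sulfanyl groups cannot be told apart here. No measurement shown explains these results.

As far as these compounds go, whether the sulfur itself matters stays open, as the sulfanyl and oxy groups also differ in what they carry. Methoxy at this place would compare with methylsulfanyl directly, and an amine or a longer chain on the sulfur would test further.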